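The compounds below may be only part of what the source reports. "The series", "measured", "known", "first", "only" and "open" are said of these compounds alone.

Of the compounds shown here, two have been measured in an assay on isolated protein with Bile acid receptor (Homo sapiens) as the target; on this read-out higher numbers stand for an effect only at larger amounts of compound and lower numbers for an effect already at smaller amounts. Compound 1 `COC(=O)/C=C/c1cccc(N(Cc2ccc(/C=C/c3c(C)cc(C)cc3C)cc2)C(=O)C(C)C)c1` gives 149 nM in this assay, and compound 2 `COC(=O)/C=C/c1cccc(N(Cc2ccc(/C=C/c3cccc(F)c3)cc2)C(=O)C2CCCCC2)c1` gives 86 nM. The two numbers lie within the scatter of each other, so on the numbers shown compound 2 is not separated from compound 1. Among the compounds with values here, compound 1 and compound 2 differ in two places at once, so no single step between measured compounds is available in this assay.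

Compound 3 `COC(=O)/C=C/c1cccc(N(Cc2ccc(/C=C/c3cccc(F)c3)cc2)C(=O)C(C)C)c1` is not yet measured. It differs from compound 2 in one place: isopropyl in place of cyclohexyl on a carbonyl carbon. Compound 1 carries the same isopropyl on its carbonyl carbon, but its second difference from compound 2 means its value is no guide to this one change on its own. Within the data shown here, with no step to rest on, a step of modest size in either direction, or none beyond the scatter, is what can be expected, and the estimated step of a 1.7-fold higher number from compound 2 to compound 3 (0.24 log units; within the scatter) is set toward a somewhat higher number. Compound 3 is expected to give 150 nM in this assay, within a range of 60 nM to 400 nM.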

Compound 3, half-maximal effective concentration: 71 nM
Compound 3: the middle estimate sits 2.1-fold (0.32 log units) above what was measured; low and high end bracket the measured number.
By their numbers in this assay, from the lowest: compounds 3, 2 and 1 (each within the scatter of the next, the first and the last beyond it).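

In this assay, the change from cyclohexyl to isopropyl on a carbonyl carbon gives a step within the scatter (a 1.2-fold lower number from compound 2 to compound 3 (0.08 log units; within the scatter)), so this position does not separate the two groups, although the group falls from 6 heavy atoms to 3 and loses its six-membered ring. Compound 3 also supplies the first one-place comparison with compound 1: with isopropyl on the carbonyl carbon in both, 3-fluorophenyl in place of 2,4,6-trimethylphenyl gives a modest step beyond the scatter (a 2.1-fold lower number from compound 1 to compound 3 (0.32 log units; beyond the scatter)), the only such step among the compounds shown. No measurement at hand accounts for the size of either step.

As far as these compounds go, it remains open whether the carbonyl carbon accepts groups of a different kind, such as an aminomethyl group, a carboxylic acid or a longer alkyl chain, with as little effect as the change from cyclohexyl to isopropyl. From the compounds shown here alone, it also remains open whether the step from 2,4,6-trimethylphenyl to 3-fluorophenyl keeps its size with cyclohexyl on the carbonyl carbon, and how a pyridyl group would read in place of either aryl group.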